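The compounds below may be only part of what the source reports. "The series", "measured", "known", "first", "only" and "open" are said of these compounds alone.

Working notes on the series in a functional assay on the whole organism for inhibition, with Nicotiana tabacum as the target; a higher number here means a weaker inhibitor, a lower number a stronger inhibitor. Compound 1 `Cc1nc(Nc2ccc(F)cc2)c2cc[nH]c2n1` gives 372000000 nM. Going by the values given here, compound 2 `COc1ccc(Nc2[nH]c(C)nc3nccc2-3)cc1` gives 661000000 nM, and compound 3 `CCCc1ccc(Nc2[nH]c(C)nc3nccc2-3)cc1` gives 105000000 nM; the single one-place step runs a 6.3-fold lower number from compound 2 to compound 3 (0.80 log units; beyond the scatter). Compound 1 thus sits second highest of the three numbers: its value and that of compound 2 lie within the scatter of each other, while compound 3 lies beyond the scatter below it. Compound 4 `Cc1nc(Nc2ccc(C#N)cc2)c2cc[nH]c2n1` differs from compound 1 by cyano in place of fluoro on an aromatic carbon. Among the compounds with values here, no measured step swaps fluoro for cyano; the only step on this aromatic carbon, propyl for methoxy, is a different change and is only a modest one. The expectation for compound 4 is therefore a step within the scatter, a 1.2-fold lower number from compound 1 to compound 4 (0.09 log units; within the scatter), with an estimated value of 300000000 nM (range 100000000 nM to 900000000 nM).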

Compound 4, half-maximal inhibitory concentration: 501000000 nM
For compound 4 the middle estimate is 1.7-fold (0.22 log units) below the measured one, and the stated range covers the measured number.
By their numbers in this assay, from the lowest: compound 3; then compounds 1, 4 and 2 (each within the scatter of the next).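

In this assay cyano in place of fluoro on this aromatic carbon gives a 1.3-fold higher number from compound 1 to compound 4 (0.13 log units; within the scatter) on the core of compound 1, so entry of a hydrogen-bond acceptor and one more heavy atom here brings no step beyond the scatter. Going by these compounds alone, the one earlier step on this aromatic carbon, a 6.3-fold lower number from compound 2 to compound 3 (0.80 log units; beyond the scatter) and beyond the scatter, involved a different pair of groups. No measurement bears on why fluoro and cyano read alike here.

From the compounds shown here alone, whether this holds beyond these two groups stays open. An amine, a carboxylic acid or a chain longer than propyl at this aromatic carbon could still read differently.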